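Working notes on two measured analogues and a third to follow

This account rests on a few compounds, and the source may have more. Where it says the series, first, only, none or still open, it means among the compounds named here.

Measured so far in an assay on HEK293 cells for displacement of a labelled ligand from 5-hydroxytryptamine receptor 7 (Homo sapiens); a higher number here means a weaker inhibitor, a lower number a stronger inhibitor:
compound 1 `COc1cccc(-n2c(=O)n(CCN3CCN(c4ccccc4C)CC3)c3ccccc32)c1` gives 2500 nM
compound 2 `Cc1ccccc1-n1c(=O)n(CCN2CCN(c3ccccc3)CC2)c2ccccc21` gives 902 nM

Compound 2 stands at the lower of the two numbers, and compound 1 lies a step beyond the usual scatter above it, so the two are distinguishable in this assay. Compound 1 and compound 2 differ from each other in two places at once, so no single-point step can be read from the pair.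

Compound 3 `COc1cccc(-n2c(=O)n(CCN3CCN(c4ccccc4)CC3)c3ccccc32)c1` has not yet been measured. It differs from compound 2 in one place: 3-methoxyphenyl in place of 2-methylphenyl on an aromatic nitrogen. The other point of difference between compound 1 and compound 2 is kept as in compound 2. Among the compounds with values here, no measured pair isolates this change, so its direction is open; a modest move toward a higher number, not confidently beyond the scatter, is expected as the step of a 1.7-fold higher number from compound 2 to compound 3 (0.22 log units; within the scatter). Compound 3 is estimated at 1500 nM, within 500 nM to 4500 nM.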

Compound 3, inhibition constant: 864 nM
Estimate against measurement, compound 3: 1.7-fold (0.24 log units) above; measured number inside the range.
By their numbers in this assay, from the lowest: compounds 3 and 2 (each within the scatter of the next); then compound 1.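

In this assay, 3-methoxyphenyl in place of 2-methylphenyl on the aromatic nitrogen gives a 1.0-fold lower number from compound 2 to compound 3 (0.02 log units; within the scatter) and so leaves the two groups indistinguishable at this position, even though the entering group carries one more heavy atom and a hydrogen-bond acceptor. Within the data shown here, the same measurement isolates the other point of difference for the first time: hydrogen in place of methyl on an aromatic carbon gives a 2.9-fold lower number from compound 1 to compound 3 (0.46 log units; beyond the scatter) and is the only single change here that lies beyond the scatter, though only modestly. Nothing available here accounts for either step.

As far as these compounds go, whether the position on the aromatic nitrogen stays this indifferent with an amine or a carboxylic acid in place of the aryl group remains open. Also open, from the compounds shown here alone, is whether chlorine in place of the methyl on that aromatic carbon would give a step of similar size.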